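Acetyl Replacing Hydrogen on the Coumarin-Lipoic Acid Conjugate Core

The source may report more compounds than this note shows. Statements on the series, on what has been measured and on what is new or still open speak of the compounds shown alone.

The measured compounds and their values:
compound 1 `O=C(CCCCC1CCSS1)NCc1cn(CCCOc2ccc3cc(-c4ccc(Cl)c(Cl)c4)c(=O)oc3c2)nn1` — 51.2%
compound 2 `O=C(CCCCC1CCSS1)NCc1cn(CCCCCOc2ccc3ccc(=O)oc3c2)nn1` — 78.5%
compound 3 `Cc1cc(=O)oc2cc(OCCCCCn3cc(CNC(=O)CCCCC4CCSS4)nn3)ccc12` — 70.3%

In a functional assay on PC-12 cells (Rattus norvegicus) for cytotoxicity, read by MTT assay, with stated times of 3 h and 2 h, tested at 20 uM (on this read-out higher numbers stand for a stronger effect at the one concentration tested and lower numbers for a weaker effect), compound 2 gives 78.5%, the highest of the three numbers. Its nearest neighbour is compound 3, which gives 70.3%, a step of a number 8.2 percentage points lower from compound 2 to compound 3 (within the scatter). Among the measured compounds shown here, the furthest is compound 1, which gives 51.2%; the gap between compound 2 and compound 1 is beyond the scatter, but no single-point step is drawn between them, so only the two values themselves speak.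

Compound 4 `CC(=O)c1cc2ccc(OCCCCCn3cc(CNC(=O)CCCCC4CCSS4)nn3)cc2oc1=O` has not yet been measured. It differs from compound 2 by acetyl in place of hydrogen on an aromatic carbon

For the measured compounds named here, the only measured step that bears on this change is the one from compound 2 to compound 3, in which a methyl replaced a hydrogen on an aromatic carbon of the shared core and gave a number 8.2 percentage points lower from compound 2 to compound 3 (within the scatter). A small group entering on an aromatic carbon of the core therefore left the read-out within the scatter. Since the acetyl is likewise a small group on an aromatic carbon, compound 4 is expected to show a step of a number 6.5 percentage points lower from compound 2 to compound 4 (within the scatter), that is, none beyond the scatter. The estimate for compound 4 in this assay is 72%, with a range from 55% to 86%.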

Compound 4, a percentage reported as activity, at one concentration (the size of the read-out at that concentration, not a potency): 20.7%
Compound 4: the middle estimate sits 51.3 percentage points above what was measured; measured number outside the range, below it.
By their numbers in this assay, from the lowest: compound 4; then compound 1; then compounds 3 and 2 (each within the scatter of the next).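

In this assay, among the compounds shown here, acetyl in place of hydrogen on this aromatic carbon, two atoms from the ring oxygen, produces a step of a number 57.8 percentage points lower from compound 2 to compound 4 (beyond the scatter), so a change of only 3 heavy atoms at this place is enough to move the read-out far beyond what the earlier compounds showed. The methyl step, a number 8.2 percentage points lower from compound 2 to compound 3 (within the scatter), involved another aromatic carbon of the same ring and a different group, so it had shown nothing about this position or about acetyl, and the two steps together show that a small group on this ring does not always leave the read-out unchanged. Nothing available here accounts for the size of the acetyl step.

The compounds shown cannot separate the effect of this position from that of the group, since only acetyl has been shown on this carbon and methyl only on the other. From the compounds shown here alone, it remains open whether a methyl, an ethyl, a carboxylic acid or an amine on this same carbon would lower the read-out as acetyl does or leave it close to that of compound 2.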